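Cyclopentyl for Butyl on Sulfur: Tolerance in Cell Culture

This account rests on a few compounds, and the source may have more. Where it says the series, first, only, none or still open, it means among the compounds named here.

Compound 1 `CCCCSc1nc(Cc2c(F)cccc2Cl)cc(=O)[nH]1` and compound 2 `O=c1cc(Cc2c(F)cccc2Cl)nc(SC2CCCC2)[nH]1` share one core, and the difference between them is cyclopentyl in place of butyl on a sulfur. Both were tested in an ADME assay on MT4 cells (Homo sapiens) for activation, read by MTT assay; a higher number here means that more compound is tolerated, a lower number that less compound is tolerated. Compound 1 reaches only a limit of the assay, > 76000 nM. Compound 2 likewise reaches only a limit, > 74000 nM. Because the limit of > 76000 nM in this assay, at which 1 of the 3 values shown sits, and the limit of > 74000 nM in this assay, at which 1 of the 3 values shown sits, are both limits, the step that the two limits leave unreadable from compound 1 to compound 2 cannot be read in either direction.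

Compound 3 `CCCCSc1nc(C(CC)c2c(F)cccc2Cl)c(C)c(=O)[nH]1` also carries butyl on a sulfur, but its core differs from that of compound 1 in more than one place, and the difference between the two cores is not broken down here. In this assay compound 3 again gives only a limit, > 3000 nM. That threshold is recorded as the limit of > 3000 nM in this assay, at which 1 of the 3 values shown sits.

Compound 4 `CCC(c1nc(SC2CCCC2)[nH]c(=O)c1C)c1c(F)cccc1Cl` has not yet been measured. It differs from compound 3 by cyclopentyl in place of butyl on a sulfur, the same change seen between compound 1 and compound 2. Because a step that the two limits leave unreadable from compound 1 to compound 2 gives no readable size, and because compound 3 stops at its own limit > 3000 nM, the step from compound 3 to compound 4 is expected to be small, a step that the limit leaves unreadable from compound 3 to compound 4. Compound 4 is therefore estimated to give about 20000 nM in this assay, with an expected range from 3000 nM to 80000 nM, and the most likely outcome is that the assay again reports only a limit rather than a number.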

Compound 4, half-maximal cytotoxic concentration: > 3000 nM
Compound 4 gave a limit, no number; the forecaster's own chance of this, stated with the estimate: 85%; the middle value is on the limit's open side.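

In this assay compound 4 gives only a limit, > 3000 nM. Compound 3 also gives only a limit, > 3000 nM. No size or direction can be read for the step from compound 3 to compound 4. The compounds shown leave open whether cyclopentyl in place of butyl on a sulfur changes how much compound is tolerated in this assay at all.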